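This account rests on a few compounds, and the source may have more. Where it says the series, first, only, none or still open, it means among the compounds named here.

Compound 1 `Clc1cccc(/N=N/N2CCCC2)c1`: >= 100000 nM (a limit of the assay)
Compound 2 `Cc1ccc(/N=N/c2ccc(NCCCN(C)C)cc2)cc1`: 50000 nM
Compound 3 `c1ccc(/N=N/N2CCN(c3ccccc3)CC2)cc1`: >= 100000 nM (a limit of the assay)

These compounds were tested in an ADME assay on Vero cells (Chlorocebus sabaeus) for cytotoxicity, read by crystal violet staining; on this read-out higher numbers stand for lower toxicity in this test and lower numbers for higher toxicity in this test. Within the data shown here, compound 2 gives 50000 nM, the only actual number in the set. The other two results are limits, not numbers: the limit of >= 100000 nM in this assay, at which 2 of the 3 values shown sit. The account now turns to compound 4 `CN(C)CCCNc1ccc(/N=N/c2ccccc2)cc1`, which has not yet been measured. It differs from compound 2 by hydrogen in place of methyl on an aromatic carbon, a change from 4-methylphenyl to phenyl: hydrogen in place of methyl on an aromatic carbon. Among the measured compounds shown here, no measured pair in the set shows this change, so its size cannot be read from the data. The expectation therefore rests on compound 2 at 50000 nM, and no shift beyond the usual scatter is foreseen in this assay. The expected size of the change is no change at the digits printed from compound 2 to compound 4 (within the scatter). For compound 4 the estimated half-maximal cytotoxic concentration is 50000 nM. The expected range of this estimate runs from 22000 nM to 100000 nM.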

Compound 4, half-maximal cytotoxic concentration: 30000 nM
The estimate for compound 4 lay 1.7-fold (0.22 log units) above the measured number, and the stated range covers the measured number.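

In this assay, among these compounds, the change of hydrogen in place of methyl on an aromatic carbon, para to a large group, gives the first step that can be read in this set: a 1.7-fold lower number from compound 2 to compound 4 (0.22 log units; within the scatter). In this one pair, then, going from 4-methylphenyl to phenyl does not separate the two compounds beyond the scatter. Compound 4 also supplies a second actual number next to that of compound 2, whereas the remaining results are limits, not numbers: the limit of >= 100000 nM in this assay, at which 2 of the 4 values shown sit.

As far as these compounds go, whether another group at this place, such as a chlorine atom, a carboxylic acid or an amine, would give a step beyond the scatter remains open. Steps to the other compounds cannot be read, and the compounds shown leave open what a longer chain in place of the dimethylaminopropyl chain would do.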